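The compounds below may be only part of what the source reports. "The series", "measured", "known", "first", "only" and "open" are said of these compounds alone.

Working notes on the series. The shared core is an unsaturated diketopiperazine-type scaffold; compound 1 `COc1ccccc1/C=c1/[nH]c(=O)/c(=C\c2ccccc2OC)n(C)c1=O` carries two methoxybenzylidene arms and a methyl on one ring nitrogen, and in a functional assay on HL-60 cells (Homo sapiens) for cytotoxicity, read by CCK-8 assay, with a stated time of 72 h (on this read-out lower numbers stand for stronger inhibition and higher numbers for weaker inhibition), compound 1 gives 16200 nM. Compound 2 `COc1ccccc1/C=c1/[nH]c(=O)/c(=C\c2cccc(Cl)c2Cl)[nH]c1=O` replaces one arm with the dichlorobenzylidene and leaves both ring nitrogens unsubstituted; in this assay compound 2 is recorded as "not active" (no number reported), so no single number exists for it. Compound 3 `C=CCn1c(=O)/c(=C\c2cccc(Cl)c2Cl)[nH]c(=O)/c1=C\c1ccccc1OC` keeps the dichlorobenzylidene arm and bears an allyl on the ring nitrogen; in this assay compound 3 gives 2000 nM. Of the two numbers in hand, compound 3 has the lowest, and the gap to compound 1 lies beyond the usual scatter of the read-out.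

Compound 4 `COc1ccccc1/C=c1\c(=O)[nH]/c(=C/c2cccc(Cl)c2Cl)c(=O)n1C` is the next member, not yet measured in this assay. It differs from compound 3 only in the substituent on the ring nitrogen: hydrogen in place of vinyl on a saturated chain carbon bound to an aromatic nitrogen. Among the measured compounds shown here, no pair of measured compounds isolates this change, so its size is not known from the data. For the measured compounds named here, compound 1, the only other member with a methyl on the ring nitrogen, gives 16200 nM in this assay, but it also differs in the second arm, so it serves only as loose orientation. The expectation is a moderate loss from compound 3 to compound 4, beyond the scatter, a 4.0-fold higher number from compound 3 to compound 4 (0.60 log units; beyond the scatter). On that basis compound 4 is estimated at 8000 nM in this assay, with a plausible range from 2500 nM to 30000 nM.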

Compound 4, half-maximal inhibitory concentration: 200 nM
Beside the measured number, compound 4's estimate is 40-fold (1.60 log units) above it; measured number outside the range, below it.
By their numbers in this assay, from the lowest: compound 4; then compound 3; then compound 1.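

In this assay, among the compounds shown here, the change of allyl to methyl, read as hydrogen in place of vinyl on a saturated chain carbon bound to an aromatic nitrogen, gives a 10-fold lower number from compound 3 to compound 4 (1.00 log units; beyond the scatter) and is the first single change measured at this position, showing that the shorter group goes with the lower number in this pair. With the methyl held constant, 2,3-dichlorophenyl in place of 2-methoxyphenyl on a double-bonded chain carbon bound to an aromatic carbon gives an 81-fold lower number from compound 1 to compound 4 (1.91 log units; beyond the scatter) and shows that, in this pair, the arm also changes the read-out beyond the scatter. Nothing in the data accounts for either step.

Compound 2 is recorded as "not active" (no number reported) in this assay, so steps involving it cannot be read, and the effect of hydrogen on the ring nitrogen remains without a number. Also open, on these data alone, are how an ethyl, a longer propyl chain or a chain ending in an amine would read at this position, and whether the allyl to methyl step would hold with two 2-methoxyphenyl arms.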